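The source may hold more compounds than are shown below. What is called first, only, known or untested is meant among the compounds shown, and "the series" means these compounds.

Among the compounds with values here, in a functional assay on MIA PaCa-2 cells (Homo sapiens) for inhibition, read by MTT assay, with a stated time of 7 days (a lower number here means a stronger inhibitor, a higher number a weaker inhibitor), three compounds have numbers so far. Compound 1 `CC(C)c1noc(N2CCN(C(=O)[C@@H]3CCCN(S(=O)(=O)c4ccc(S(=O)(=O)C5CCC5)cc4)C3)CC2)n1` gives 70 nM, compound 2 `CCN(CC)S(=O)(=O)c1ccc(S(=O)(=O)N2CCC[C@@H](C(=O)N3CCN(c4nc(C)no4)CC3)C2)cc1` gives 250 nM, and compound 3 `CC(C)NS(=O)(=O)c1ccc(S(=O)(=O)N2CCC[C@@H](C(=O)N3CCN(c4nc(C(C)C)no4)CC3)C2)cc1` gives 2600 nM, the highest number of the three. Compound 4 `CCN(CC)S(=O)(=O)c1ccc(S(=O)(=O)N2CCC[C@@H](C(=O)N3CCN(c4nc(C(C)C)no4)CC3)C2)cc1` has not yet been measured. It differs from compound 3 in one place, with diethylamino in place of isopropylamino on a sulfonyl sulfur. Within the data shown here, only one measured step touches this position: a 37-fold higher number from compound 1 to compound 3 (1.57 log units; beyond the scatter), where isopropylamino took the place of cyclobutyl on a sulfonyl sulfur. That step was large and beyond the scatter, but it did not involve diethylamino. Among the measured compounds shown here, compound 2 does carry diethylamino there and gives 250 nM, although it differs from compound 4 elsewhere, so no measured pair isolates this swap. A large move toward a lower number is therefore expected, beyond the scatter. The expected change is an 8.7-fold lower number from compound 3 to compound 4 (0.94 log units; beyond the scatter). For compound 4 the estimated value is 300 nM, with an expected range from 90 nM to 1000 nM.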

Compound 4, half-maximal inhibitory concentration: 50 nM
Compound 4: middle estimate off by 6.0-fold (0.78 log units), on the high side, and the stated range ends above it.
By their numbers in this assay, from the lowest: compounds 4 and 1 (each within the scatter of the next); then compound 2; then compound 3.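

Within this assay, the diethylamino swap on the sulfonyl sulfur, now isolated from any other change, gives a 52-fold lower number from compound 3 to compound 4 (1.72 log units; beyond the scatter), so the group on this sulfur alone can move the number by a large amount. Diethylamino and cyclobutyl at this place cannot be told apart, with a 1.4-fold lower number from compound 1 to compound 4 (0.15 log units; within the scatter), which shows that the weak number of compound 3 goes with isopropylamino rather than with every group other than cyclobutyl. The result also gives the first view of a second place, since isopropyl in place of methyl on an aromatic carbon, with diethylamino held fixed, gives a 5.0-fold lower number from compound 2 to compound 4 (0.70 log units; beyond the scatter).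

The compounds shown leave open how groups such as dimethylamino or ethylamino would behave on this sulfur, and so whether the hydrogen-bond donor that isopropylamino carries and diethylamino lacks goes with the shift. No measurement at hand explains these steps.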